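Two difluoronitrophenyl arrangements tested for cytotoxicity

A few compounds are considered here, and "the series" means these few. Any claim that something is new, unique, unknown or untested is made for them only; others in the source may bear on it.

Compound 1 `Nc1nc(N)c(CCCN(Cc2ccc(NC(CCC(=O)O)C(=O)O)cc2)c2cc(F)c(F)cc2[N+](=O)[O-])c(O)n1`: > 100000 nM
Compound 2 `Nc1nc(N)c(CCCN(Cc2ccc(NC(CCC(=O)O)C(=O)O)cc2)c2ccc([N+](=O)[O-])c(F)c2F)c(O)n1`: > 100000 nM
Compound 3 `CC(C)(C)OC(=O)CCC(Nc1ccc(CN(CCCc2c(N)nc(N)nc2O)c2ccc([N+](=O)[O-])c(F)c2F)cc1)C(=O)OC(C)(C)C`: 36000 nM

In a functional assay on CCRF-CEM cells (Homo sapiens) for cytotoxicity, in the absence of a further agent (on this read-out higher numbers stand for weaker inhibition and lower numbers for stronger inhibition), compound 1 gives > 100000 nM, which is a limit of the assay and not a number. Compound 2 likewise gives only a limit, > 100000 nM. Among the measured compounds shown here, compound 3 gives the one real number, 36000 nM. The change from compound 2 to compound 1, (4,5-difluoro-2-nitrophenyl in place of 2,3-difluoro-4-nitrophenyl on an amine nitrogen), produces a step that the two limits leave unreadable from compound 2 to compound 1, since both sit at the limit of > 100000 nM in this assay, at which 2 of the 3 values shown sit. The cores of compound 2 and compound 3 differ, but that difference is not broken down here. Compound 4 `CC(C)(C)OC(=O)CCC(Nc1ccc(CN(CCCc2c(N)nc(N)nc2O)c2cc(F)c(F)cc2[N+](=O)[O-])cc1)C(=O)OC(C)(C)C` carries the same kind of change relative to compound 3, (4,5-difluoro-2-nitrophenyl in place of 2,3-difluoro-4-nitrophenyl on an amine nitrogen), at a place described in the same words. Because the measured step that the two limits leave unreadable from compound 2 to compound 1 is unreadable, compound 4 is expected to stay near compound 3, with an estimated step of a 1.1-fold higher number from compound 3 to compound 4 (0.05 log units; within the scatter). Compound 4 is thus estimated at 40000 nM, between 10000 nM and 150000 nM.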

Compound 4, half-maximal inhibitory concentration: 3400 nM
The estimate for compound 4 lay 12-fold (1.07 log units) above the measured number, and the stated range ends above it.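

Putting 4,5-difluoro-2-nitrophenyl in place of 2,3-difluoro-4-nitrophenyl on an amine nitrogen gives, in this assay, an 11-fold lower number from compound 3 to compound 4 (1.02 log units; beyond the scatter), so on this core the arrangement of the same atoms matters. The same change on the core of compound 2 cannot be read, because both compounds in that pair give a limit of the assay and not a number: the limit of > 100000 nM in this assay, at which 2 of the 4 values shown sit. The result therefore shows a large step on one core, but it does not show whether that step carries over to the other core.

Going by these compounds, it remains open how the change behaves on a core with a methyl ester or an amide in place of the esters of compound 3. On these data alone, it is also open whether chlorine in place of fluorine on the nitrophenyl ring would give a similar step.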